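Chloro in Place of Hydrogen on Compound 3

A few compounds are considered here, and "the series" means these few. Any claim that something is new, unique, unknown or untested is made for them only; others in the source may bear on it.

In a functional assay on DU-145 cells (Homo sapiens) for inhibition (a lower number here means a stronger inhibitor, a higher number a weaker inhibitor), compound 1 `CCOc1ccc(Br)cc1-c1cc(Nc2ccc(C#N)cc2)nc(N)n1` gives 400 nM and compound 2 `CCOc1ccc(Br)cc1-c1cc(Nc2ccc(C(C)=O)cc2)nc(N)n1` gives 90 nM. Compound 3 `CCOc1ccc(Br)cc1-c1cc(Nc2ccccc2)nc(N)n1` reads > 1000 nM, which is a limit of the assay and not a number. Compound 4 `CCOc1ccc(Br)cc1-c1cc(Nc2ccc(Cl)cc2)nc(N)n1` differs from it by one change: chloro in place of hydrogen on an aromatic carbon, para to a large group. For the measured compounds named here, two measured steps bear on this. Hydrogen in place of cyano gave an at least 2.5-fold higher number from compound 1 to compound 3 (0.39 log units; beyond the scatter), and hydrogen in place of acetyl gave an at least 11-fold higher number from compound 2 to compound 3 (1.04 log units; beyond the scatter). Read in reverse, both suggest that a group in place of that hydrogen lowers the number. On that basis the expected change is an at least 2.5-fold lower number from compound 3 to compound 4 (0.39 log units; beyond the scatter), a modest one towards stronger inhibition in this assay. Compound 4 is estimated at 400 nM, with an expected range of 100 nM to 1500 nM.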

Compound 4, half-maximal inhibitory concentration: 80 nM
Compound 4: middle estimate off by 5.0-fold (0.70 log units), on the high side; measured number below the stated range.
By their numbers in this assay, from the lowest: compounds 4 and 2 (each within the scatter of the next); then compound 1. At a limit, above all of these: compound 3.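

In this assay chloro in place of hydrogen gives an at least 12-fold lower number from compound 3 to compound 4 (1.09 log units; beyond the scatter) on the ring of the anilino group, so a single chlorine atom with 0 hydrogen-bond acceptors is enough at this position. Chloro gives a 1.1-fold lower number from compound 2 to compound 4 (0.05 log units; within the scatter) in place of acetyl and a 5.0-fold lower number from compound 1 to compound 4 (0.70 log units; beyond the scatter) in place of cyano, so it does as well here as acetyl and better than cyano. The reading for compound 3 is a limit and not a number: the limit of > 1000 nM in this assay, at which 1 of the 4 values shown sits.

On these data alone, whether fluoro, methyl or an amine on the same carbon would do the same remains open. So does whether chloro would act alike on another carbon of this ring.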